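This account rests on a few compounds, and the source may have more. Where it says the series, first, only, none or still open, it means among the compounds named here.

Measured so far in a functional assay on A549 cells (Homo sapiens) for inhibition, read by MTT assay, with a stated time of 24 h; on this read-out higher numbers stand for weaker inhibition and lower numbers for stronger inhibition:

compound 1 `CCOC(=O)C1=Cc2ccccc2OC1(OCc1cc(-c2ccc(F)cc2F)no1)C(F)(F)F`: > 150000 nM
compound 2 `CCOC(=O)C1=Cc2ccccc2OC1(OCc1cn(CC(=O)NC2CCCCC2)nn1)C(F)(F)F`: 9900 nM
compound 3 `O=C(O)C1=Cc2ccccc2OC1(OCc1cc(-c2ccc(F)cc2)no1)C(F)(F)F`: > 150000 nM

Among the measured compounds shown here, compound 2 gives 9900 nM in this assay, and that is the only number among the three values shown. The value of compound 1 is a limit of the assay, not a number. The value of compound 3 is likewise a limit of the assay. Two of the three values therefore sit at the limit of > 150000 nM in this assay, at which 2 of the 3 values shown sit, so compound 2 is the only anchor for any estimate. For the measured compounds named here, no pair of measured compounds differs in a single place, so no measured step tells how large a change of the group on the triazole ring nitrogen can be.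

Compound 4 `CCOC(=O)C1=Cc2ccccc2OC1(OCc1cn(-c2cccc(C(F)(F)F)c2)nn1)C(F)(F)F` has not yet been measured in this assay. It differs from compound 2 by 3-(trifluoromethyl)phenyl in place of (cyclohexylcarbamoyl)methyl on an aromatic nitrogen. The group that leaves carries the only hydrogen-bond donor and acceptor of that substituent; the group that enters carries none. Going by the values given here, with no measured step of this kind, the expectation is for a step of no clear direction and no more than the scatter, carrying a fair chance that the assay returns only a limit. Compound 4 is expected to give 15000 nM, with a range of 3000 nM to 90000 nM. The implied step a 1.5-fold higher number from compound 2 to compound 4 (0.18 log units; within the scatter) is an estimate, not a measurement.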

Compound 4, half-maximal inhibitory concentration: > 150000 nM
Compound 4 gave a limit, no number; the forecaster's own chance of this, stated with the estimate: 30%; middle value at least 10-fold (1.00 log units) away from the limit.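

Among the compounds shown here, replacing (cyclohexylcarbamoyl)methyl with 3-(trifluoromethyl)phenyl on an aromatic nitrogen gives an at least 15-fold higher number from compound 2 to compound 4 (1.18 log units; beyond the scatter) in this assay, the only single-place step measured, and it shows that a change at this position can be large. As far as these compounds go, the value of compound 4 is a limit, not a number, so the true size of the step stays unknown beyond its printed bound. Of the two groups compared at this position, only (cyclohexylcarbamoyl)methyl gives a number, and compound 2 remains the sole numerical anchor: the limit of > 150000 nM in this assay, at which 3 of the 4 values shown sit.

The step swaps the amide, the carbon-only non-aromatic ring and the aromatic ring in one move, so the compounds shown do not tell which of these parts matters. From the compounds shown here alone, what a benzyl group or a short chain ending in a carboxylic acid would give on this nitrogen also stays open.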